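Compound 3 to compound 4: methoxy on the core

The source may hold more compounds than are shown below. What is called first, only, known or untested is meant among the compounds shown, and "the series" means these compounds.

Measured in a functional assay on MCF7 cells (Breast, Homo sapiens); on this read-out higher numbers stand for an effect only at larger amounts of compound and lower numbers for an effect already at smaller amounts:
- compound 1 `Oc1nc(-c2cccc(F)c2)nc2ccccc12`: > 20 ug/mL
- compound 2 `COc1cc2nc(-c3cccc(F)c3)nc(O)c2cc1OC`: "not active" (no number reported)
- compound 3 `COc1cccc(-c2nc(O)c3ccccc3n2)c1`: > 20 ug/mL

Compound 3 gives > 20 ug/mL, which is a limit and not a number. Compound 1 gives > 20 ug/mL, which is also only a limit. Among the measured compounds shown here, the measured series therefore rests on (the limit of > 20 ug/mL in this assay, at which 2 of the 3 values shown sit), and no compound has yet given a number in this assay.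

Compound 4 `COc1cccc(-c2nc(O)c3cc(OC)ccc3n2)c1` differs from compound 3 in one place: methoxy in place of hydrogen on an aromatic carbon. The new methoxy sits on an aromatic carbon of a six-membered aromatic ring of carbon only, part of a fused or bridged system of two rings.

For the measured compounds named here, the only measured step, a step that the two limits leave unreadable from compound 1 to compound 3, puts methoxy in place of fluoro elsewhere and offers no size to carry over. The nearest guide is compound 2, which also carries methoxy on the shared core and is reported as "not active" (no number reported). On that reading, no step beyond the scatter is expected, in either direction, and a report of only a limit is the likeliest outcome. The estimated step is a step that the limit leaves unreadable from compound 3 to compound 4. Compound 4 is expected to read 25 ug/mL, with an estimated range from 12 ug/mL to 50 ug/mL.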

Compound 4, concentration for half-maximal effect: 37.5 ug/mL
For compound 4 the middle estimate is 1.5-fold (0.18 log units) below the measured one; the measured number falls inside the stated range.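

In this assay compound 4 gives 37.5 ug/mL. Among the compounds shown here, compound 3 gives > 20 ug/mL, which is only a limit, so no step from compound 3 to compound 4 can be read. The compounds shown leave open whether methoxy in place of hydrogen on the shared core changes the read-out at all, and in which direction: the limit of > 20 ug/mL in this assay, at which 2 of the 4 values shown sit.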